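Swapping the Ring on the Chain Carbon of Compound 2

The source may report more compounds than this note shows. Statements on the series, on what has been measured and on what is new or still open speak of the compounds shown alone.

Compound 1 `CCCSc1nc(N/N=C(\C)c2ccc(OC)cc2)c2nnn(Cc3ccccc3)c2n1`: 44300 nM
Compound 2 `CCCSc1nc(N/N=C(\C)c2ccccc2O)c2nnn(Cc3ccco3)c2n1`: 4760 nM
Compound 3 `CCCSc1nc(N/N=C/c2ccc(C)cc2)c2nnn(Cc3ccccc3)c2n1`: a limit, > 64000 nM

In a functional assay on MGC-803 cells (Homo sapiens) for antiproliferative activity, read by MTT assay, with a stated time of 72 h (a higher number here means a weaker inhibitor, a lower number a stronger inhibitor), compound 2 gives 4760 nM, the lowest of the two numbers at hand. Compound 1 gives 44300 nM in this assay, a higher number by a margin beyond the scatter. For compound 3 this assay reports only a limit, > 64000 nM, and no number. Compound 4 `CCCSc1nc(N/N=C(\C)c2ccccc2O)c2nnn(Cc3cccc(Cl)c3)c2n1` has not yet been measured in this assay. It differs from compound 2 in one place: 3-chlorophenyl in place of furan-2-yl on a saturated chain carbon bound to an aromatic nitrogen. Within the data shown here, no pair of measured compounds differs in a single place, so there is no measured step to lean on. The step from compound 2 to compound 4 is expected to be a 1.1-fold higher number from compound 2 to compound 4 (0.02 log units; within the scatter), a change not beyond the scatter in either direction. Compound 4 is expected to give 5000 nM, with a range from 1500 nM to 16000 nM.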

Compound 4, half-maximal inhibitory concentration: 6500 nM
Compound 4: middle estimate off by 1.3-fold (0.11 log units), on the low side; measured number inside the range.
By their numbers in this assay, from the lowest: compounds 2 and 4 (each within the scatter of the next); then compound 1. At a limit, above all of these: compound 3.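

In this assay, setting 3-chlorophenyl in place of furan-2-yl on a saturated chain carbon bound to an aromatic nitrogen gives a 1.4-fold higher number from compound 2 to compound 4 (0.14 log units; within the scatter). Among these compounds, this is the first single-place step available, and it shows that this place holds either ring without a difference beyond the scatter, even though the hydrogen-bond acceptor of furan-2-yl leaves with it. Nothing at hand gives a reason for this result. Still open is how a group carrying a carboxylic acid or an amine would read at this place, since both rings shown here are aromatic.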